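The source may report more compounds than this note shows. Statements on the series, on what has been measured and on what is new or still open speak of the compounds shown alone.

Working notes on the series. The shared core is carried by compound 1 `Cc1cccc(N2CCC(C(=O)Nc3ccc4c(c3)NC(=O)CO4)CC2)c1`, compound 2 `O=C1COc2ccc(NC(=O)C3CCN(c4ccccc4Br)CC3)cc2N1` and compound 3 `Cc1ccccc1N1CCC(C(=O)Nc2ccc3c(c2)NC(=O)CO3)CC1`, which differ only in the aryl group on the amine nitrogen of the ring. In an assay on HEK293 cells for displacement of a labelled ligand from transient receptor potential cation channel subfamily V member 1 (Homo sapiens) (on this read-out lower numbers stand for stronger inhibition and higher numbers for weaker inhibition), compound 1 gives 225 nM, compound 2 gives 71 nM and compound 3 gives 61 nM. Among the measured compounds shown here, compound 3 thus holds the lowest of the three numbers, though its gap to compound 2 is within the scatter; only the step from compound 1 stands clear, with a 3.7-fold lower number from compound 1 to compound 3 (0.57 log units; beyond the scatter), and the parallel step a 3.2-fold lower number from compound 1 to compound 2 (0.50 log units; beyond the scatter) points the same way.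

Compound 4 `CC(C)c1ccccc1N1CCC(C(=O)Nc2ccc3c(c2)NC(=O)CO3)CC1` is not yet measured. It differs from compound 3 by isopropyl in place of methyl on an aromatic carbon. The step that bears most directly on this place is a 1.2-fold lower number from compound 2 to compound 3 (0.07 log units; within the scatter), which shows that swapping one group for another on that same aromatic carbon left the number within the scatter. For the measured compounds named here, no measured step tests a larger group on that carbon, so the size of the change is open. In this assay compound 4 is therefore expected to stay close to compound 3, with a step of about a 1.3-fold higher number from compound 3 to compound 4 (0.12 log units; within the scatter), which lies within the scatter. The estimate for compound 4 is 80 nM, with a range from 30 nM to 250 nM.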

Compound 4, inhibition constant: 78 nM
Beside the measured number, compound 4's estimate is 1.0-fold (0.01 log units) above it; measured number inside the range.
By their numbers in this assay, from the lowest: compounds 3, 2 and 4 (each within the scatter of the next); then compound 1.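

Among the compounds shown here, compound 4 supplies the test of a larger group on this aromatic carbon that the earlier compounds lacked: in this assay, isopropyl in place of methyl gives a 1.3-fold higher number from compound 3 to compound 4 (0.11 log units; within the scatter) and isopropyl in place of bromo gives a 1.1-fold higher number from compound 2 to compound 4 (0.04 log units; within the scatter), so methyl, bromo and isopropyl at this place, ortho to a large group, cannot be told apart. The step to the compound carrying the 3-methylphenyl group stands apart, with a 2.9-fold lower number from compound 1 to compound 4 (0.46 log units; beyond the scatter), so in this assay all three compounds with a group at this place now lie clear of compound 1, and none of the four goes against that. No measurement at hand offers an explanation for the flat response to the change from methyl to isopropyl.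

Still open, going by these compounds, is whether a tert-butyl group, a methoxy group, an amine or a carboxylic acid on this aromatic carbon would keep the number in the same band. Also open, on these data alone, is whether a 3-isopropylphenyl group would stay with compound 1 or join compound 2, compound 3 and compound 4.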